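The source may report more compounds than this note shows. Statements on the series, on what has been measured and on what is new or still open speak of the compounds shown alone.

Of the compounds shown here, three built on one shared core have so far been tested in an in vitro assay on HEK385-7 cells for displacement of a labelled ligand from prostaglandin D2 receptor 2 (Homo sapiens); on this read-out lower numbers stand for stronger inhibition and higher numbers for weaker inhibition. Compound 1 `O=C(O)Cc1sc(NC(=O)c2ccccc2)nc1-c1ccc(Cl)cc1` gives 520 nM, compound 2 `O=C(O)Cc1sc(C(c2ccccc2)c2ccc(F)c(F)c2)nc1-c1ccc(F)cc1` gives 10 nM, and compound 3 `N#Cc1cc(-c2nc(C(c3ccc(F)cc3)c3ccc(F)cc3)sc2CC(=O)O)ccc1F` gives 57 nM. Compound 3 therefore stands in the middle of the set: its number is the second highest of the three, compound 2 shows the lower figure and compound 1 the higher one, and both of those gaps lie beyond the usual scatter of repeated measurements of this kind.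

The next compound, compound 4 `Cc1cc(-c2nc(C(c3ccc(F)cc3)c3ccc(F)cc3)sc2CC(=O)O)cnc1N`, keeps the core and the carboxymethyl group of compound 3 but carries a different aromatic group at the same place: 6-amino-5-methylpyridin-3-yl in place of 3-cyano-4-fluorophenyl on an aromatic carbon. Both the group that leaves and the group that enters are single six-membered aromatic rings, so the general outline of the molecule is kept while the substitution pattern on that ring is changed.

For the measured compounds named here, no measured pair isolates this particular change, so there is no directly comparable step to lean on, and the expectation has to be cautious. The expected step in this assay is a 1.4-fold higher number from compound 3 to compound 4 (0.15 log units; within the scatter), which may well fall within the scatter or lean slightly toward weaker binding. Compound 4 is accordingly estimated at 80 nM, within a range from 25 nM to 250 nM.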

Compound 4, half-maximal inhibitory concentration: 880 nM
The estimate for compound 4 lay 11-fold (1.04 log units) below the measured number; measured number above the stated range.
By their numbers in this assay, from the lowest: compound 2; then compound 3; then compounds 1 and 4 (each within the scatter of the next).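

The change from 3-cyano-4-fluorophenyl to 6-amino-5-methylpyridin-3-yl, on the aromatic carbon next to the ring nitrogen, brings a 15-fold higher number from compound 3 to compound 4 (1.19 log units; beyond the scatter) in this assay and shows that this position does not accept every single six-membered aromatic ring equally: keeping the general outline of the molecule is not enough to keep the inhibition. Several things differ within this one swap, since the nitrile and the fluorine leave while a ring nitrogen, an amine and a methyl group enter, so the step belongs to the whole group and not to any one of these parts. Nothing available here explains why the number rises so far.

On these data alone, whether the weaker inhibition follows the amine, the methyl group or the ring nitrogen remains open, and a 6-aminopyridin-3-yl group without the methyl or a 5-methylpyridin-3-yl group without the amine would help to separate them. Also open, as far as these compounds go, is how a plain phenyl group at this position would compare with the two rings seen so far.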